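Swapping one amide amine for a pyrrolidine ring

This account rests on a few compounds, and the source may have more. Where it says the series, first, only, none or still open, it means among the compounds named here.

Measured so far:
compound 1, `CCOc1cc(NC(=O)C2(NC(=O)c3ccc4c(C5CCCC5)c(-c5ncc(Cl)cn5)n(C)c4c3)CCC2)ccc1/C=C/C(=O)OCCOCCOC`: 0.85 h
compound 2, `CCOc1cc(NC(=O)C2(NC(=O)c3ccc4c(C5CCCC5)c(-c5ncc(Cl)cn5)n(C)c4c3)CCC2)ccc1/C=C/C(=O)OCC(=O)N(C)C(C)C`: 0.65 h

Both compounds were tested in an ADME assay (liver) for pharmacokinetics, with Liver microsome (Homo sapiens) as the target, using microsomes; a higher number here means that the compound lasts longer, a lower number that the compound disappears faster. Compound 1 gives 0.85 h, and compound 2 gives 0.65 h; the two stand within the scatter of each other, so on these numbers compound 2 cannot be told apart from compound 1. Going by the values given here, the only step seen so far, a 1.3-fold lower number from compound 1 to compound 2 (0.12 log units; within the scatter), changed the group on the chain carbon bound to the oxygen of the ester.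

Compound 3, `CCOc1cc(NC(=O)C2(NC(=O)c3ccc4c(C5CCCC5)c(-c5ncc(Cl)cn5)n(C)c4c3)CCC2)ccc1/C=C/C(=O)OCC(=O)N1CCCC1`, differs from compound 2 at a different spot: pyrrolidin-1-yl in place of isopropyl(methyl)amino on a carbonyl carbon. Among the compounds with values here, no measured step touches this amide amine, so the only guide is that the one change made so far in this end of the molecule stayed within the scatter. The expectation for a 1.1-fold lower number from compound 2 to compound 3 (0.03 log units; within the scatter) is therefore no step beyond the scatter. For compound 3 the estimated half-life is 0.6 h, with a range from 0.3 h to 1.3 h.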

Compound 3, half-life: 1.65 h
Compound 3: the middle estimate sits 2.8-fold (0.44 log units) below what was measured; measured number outside the range, above it.
By their numbers in this assay, from the lowest: compounds 2, 1 and 3 (each within the scatter of the next, the first and the last beyond it).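

In this assay, going by these compounds alone, this amide amine is the first place where a change moves the half-life beyond the scatter: a 2.5-fold higher number from compound 2 to compound 3 (0.40 log units; beyond the scatter) is a modest step, but a real one on these numbers. The two groups have the same 5 heavy atoms, 4 carbon and 1 nitrogen, so the step goes with closing those atoms into the ring of pyrrolidin-1-yl, not with a change in atom count. With a 1.9-fold higher number from compound 1 to compound 3 (0.29 log units; within the scatter) as the other new step, compound 3 cannot be told apart from compound 1.

Nothing shown explains the difference between compound 2 and compound 3. A piperidine or morpholine ring, or an open dimethylamino group, on the same carbonyl carbon could show whether ring size, ring atoms or simply having a ring matters here.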